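Aryl for alkyl on the five-membered ring: compound 4

The compounds below may be only part of what the source reports. "The series", "measured", "known", "first", "only" and "open" are said of these compounds alone.

Compound 1, `CCCCCCOc1ccc(-n2cnnc2CCCCCC)cc1`. In a functional assay on the whole organism (strain C57B/6) with Mus musculus as the target, in the maximal electroshock model (on this read-out lower numbers stand for an effect already at smaller amounts and higher numbers for an effect only at larger amounts of compound), compound 1 gives > 40 mg/kg, a limit of the assay.
Compound 2, `CCCCCCCc1nncn1-c1ccc(OCCCCCC)cc1`. In this assay compound 2 gives > 40 mg/kg, again a limit.
Compound 3, `CCCCCCOc1ccc(-n2cnnc2-c2ccc(Cl)cc2)cc1`. In this assay compound 3 gives 19.7 mg/kg.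

Compound 2 thus stands only at a limit (the limit of > 40 mg/kg in this assay, at which 2 of the 3 values shown sit). The step from compound 1 to compound 2 is not readable a step that the two limits leave unreadable from compound 1 to compound 2. Compound 4, `CCCCCCOc1ccc(-n2cnnc2-c2ccc(C)cc2)cc1`, differs from compound 2 by 4-methylphenyl in place of heptyl on an aromatic carbon. The measured steps that bear on it both exchange a chain for 4-chlorophenyl: an at least 2.0-fold lower number from compound 2 to compound 3 (0.30 log units; that floor lies within the scatter) and an at least 2.0-fold lower number from compound 1 to compound 3 (0.30 log units; that floor lies within the scatter). The same direction is expected here, a lower number in this assay, with an expected size of an at least 1.6-fold lower number from compound 2 to compound 4 (0.20 log units; that floor lies within the scatter), resting on a floor that lies within the scatter. Compound 4 is estimated at 25 mg/kg, between 10 mg/kg and 60 mg/kg.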

Compound 4, dose for half-maximal effect: 11.4 mg/kg
The estimate for compound 4 lay 2.2-fold (0.34 log units) above the measured number, within the range that was stated.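

In this assay, aryl in place of a chain on the aromatic carbon between two ring nitrogen atoms now gives steps beyond the scatter: an at least 3.5-fold lower number from compound 2 to compound 4 (0.54 log units; beyond the scatter), and an at least 3.5-fold lower number from compound 1 to compound 4 (0.54 log units; beyond the scatter). Methyl in place of chloro gives a 1.7-fold lower number from compound 3 to compound 4 (0.24 log units; within the scatter), so the 4-methylphenyl and 4-chlorophenyl groups cannot be told apart here. Compound 1 and compound 2 each stand at a limit, and both chain steps are floors only: the limit of > 40 mg/kg in this assay, at which 2 of the 4 values shown sit.

Still open, as far as these compounds go, is whether trifluoromethyl or an amine in place of that methyl holds this level, and whether unsubstituted phenyl does.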